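Amide tail variation: compound 2 to compound 3

The source may report more compounds than this note shows. Statements on the series, on what has been measured and on what is new or still open speak of the compounds shown alone.

Measured so far:
compound 1 `CC[C@@H](C)[C@H](NC(=O)c1ccc(C(CC)(CC)c2ccc(OCC(=O)C(C)(C)C)c(C)c2)n1CC)C(=O)OC`: 590 nM
compound 2 `CCn1c(C(=O)NCCCN(C)C)ccc1C(CC)(CC)c1ccc(OCC(=O)C(C)(C)C)c(C)c1`: 96 nM

In an assay on HL-60 cells for agonist activity at vitamin D3 receptor (Homo sapiens), read by microscopy, with a stated time of 96 h (a lower number here means that less compound is needed, a higher number that more compound is needed for the effect), compound 1 gives 590 nM, and in this assay compound 2 gives 96 nM. Among the measured compounds shown here, the one measured step is a 6.1-fold lower number from compound 1 to compound 2 (0.79 log units; beyond the scatter), so compound 2 stands at the lower of the two numbers, with compound 1 the only neighbour and that neighbour beyond the scatter.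

Compound 3 `CCN(CC)CCCNC(=O)c1ccc(C(CC)(CC)c2ccc(OCC(=O)C(C)(C)C)c(C)c2)n1CC` keeps the shared core of compound 2 and differs only at the far end of the amide substituent: diethylamino in place of dimethylamino on a saturated chain carbon, three bonds along the chain from an amide-type nitrogen. For the measured compounds named here, no measured step bears directly on this change; the only step, a 6.1-fold lower number from compound 1 to compound 2 (0.79 log units; beyond the scatter), swapped the whole group on the amide-type nitrogen rather than the amine at its end, so it gives no direction for this smaller swap. With the amine kept and only its two methyl groups enlarged to ethyl groups, the expectation is a step no larger than the scatter, a 1.1-fold lower number from compound 2 to compound 3 (0.03 log units; within the scatter).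

The estimate for compound 3 in this assay is therefore 90 nM, expected to fall between 40 nM and 220 nM.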

Compound 3, half-maximal effective concentration: 22 nM
For compound 3 the middle estimate is 4.1-fold (0.61 log units) above the measured one, and the stated range ends above it.
By their numbers in this assay, from the lowest: compound 3; then compound 2; then compound 1.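

Notes on the amide tail: in this assay the end of the tail matters independently of the rest of the amide substituent, since the swap of diethylamino for dimethylamino, on an otherwise unchanged chain, gives a 4.4-fold lower number from compound 2 to compound 3 (0.64 log units; beyond the scatter) and so moves the number beyond the scatter. The whole-group replacement of 1-(methoxycarbonyl)-2-methylbutyl by 3-(diethylamino)propyl gives a 27-fold lower number from compound 1 to compound 3 (1.43 log units; beyond the scatter), a larger step than the one with 3-(dimethylamino)propyl, a 6.1-fold lower number from compound 1 to compound 2 (0.79 log units; beyond the scatter), so the size of the gain from this replacement depends on the groups carried by the amine. Nothing available accounts for the difference between the diethylamino and dimethylamino compounds.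

On these data alone, with only these two amine ends, no trend with the size of the groups on the nitrogen can be claimed, and it remains open whether dipropylamino, or a pyrrolidine or piperidine ring closed on the same nitrogen, would continue the direction seen here. Also open, as far as these compounds go, is how diethylamino behaves on a 2-carbon ethyl chain or a longer butyl chain.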